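The compounds below may be only part of what the source reports. "The series", "measured", "known", "first", "only" and "open" are said of these compounds alone.

- Compound 1 `C[C@H](Cc1ccccc1)[C@H]1CCCC(=O)O1`: > 100000 nM
- Compound 2 `COc1ccc(/C=C/[C@H]2CC=CC(=O)O2)cc1`: > 100000 nM

In a functional assay on MCF7 cells (Homo sapiens) for antiproliferative activity, read by luminescence and CellTiter-Glo, with a stated time of 48 h (a lower number here means a stronger inhibitor, a higher number a weaker inhibitor), compound 1 gives > 100000 nM, which is a limit of the assay and not a number. Compound 2 gives > 100000 nM, which is likewise a limit. The whole record so far can be put briefly: the limit of > 100000 nM in this assay, at which 2 of the 2 values shown sit. Compound 1 therefore has no true number to stand on, and it cannot be ranked against compound 2.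

Compound 3 `C[C@@H](Cc1ccccc1)[C@H]1CCCC(=O)O1` has not yet been measured. It is a close relative of compound 1, and the change is purely one of spatial arrangement: the two compounds have the same atoms and bonds and differ only in configuration as drawn: 1 of 2 stereo elements differ; a stereocentre at a saturated chain carbon is drawn R in compound 1 and S in compound 3. No atom leaves or enters.

Among the measured compounds shown here, no pair of measured compounds shows how far a change of this kind can move the result. With nothing to suggest otherwise, no step beyond the usual scatter is expected in this assay, and compound 3 will most likely be reported as a limit too. The estimated change is a step that the limit leaves unreadable from compound 1 to compound 3, which is expected to be small. For compound 3 the expected value is 130000 nM, with an estimated range from 50000 nM to 300000 nM.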

Compound 3, half-maximal inhibitory concentration: > 100000 nM
Compound 3: a limit, no number; the forecaster's own chance of this, stated with the estimate: 85%; the middle value lies beyond the limit too.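

In this assay compound 3 gives > 100000 nM, which is a limit of the assay and not a number. Among the compounds shown here, compound 1 also sits at a limit, so no step between compound 1 and compound 3 can be read. The compounds shown leave open whether the configuration at the saturated chain carbon can alter antiproliferative activity at all.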